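This account rests on a few compounds, and the source may have more. Where it says the series, first, only, none or still open, it means among the compounds named here.

Compound 1 `CNS(=O)(=O)c1ccc(-c2cnc(N)c(-c3ccc(OC)nc3)c2)cc1` and compound 2 `COc1ccc(-c2cc(-c3ccc4nccn4c3)cnc2N)cn1` are the measured compounds. In a physicochemical assay for solubility, read by nephelometry, measured as kinetic solubility, at pH 2 (a higher number here means a more soluble compound, a lower number a less soluble compound), compound 1 gives > 100 ug/mL, which is a limit of the assay rather than a number. In this assay compound 2 likewise reaches only a limit, > 100 ug/mL. Compound 1 therefore stands at the limit of > 100 ug/mL in this assay, at which 2 of the 2 values shown sit. Compound 3 `CNC(=O)c1ccc(-c2cnc(N)c(-c3ccc(OC)nc3)c2)cc1` differs from compound 1 in one place: methylcarbamoyl in place of methylsulfamoyl on an aromatic carbon. For the measured compounds named here, no step between measured compounds is known here, so the direction is open. For compound 3 the expected change is a step that the limit leaves unreadable from compound 1 to compound 3, no further than the scatter. Compound 3 is estimated at 150 ug/mL, between 60 ug/mL and 400 ug/mL, most likely again reported only as a limit.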

Compound 3, solubility: 50 ug/mL
Compound 3: the middle estimate sits 3.0-fold (0.48 log units) above what was measured; measured number below the stated range.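

Compound 3 is the only compound shown here that gives a number rather than a limit, so this position is the first place where a change can be seen at all. In this assay, methylcarbamoyl in place of methylsulfamoyl on an aromatic carbon, para to a large group, gives an at least 2.0-fold lower number from compound 1 to compound 3 (0.30 log units; that floor lies within the scatter) as the smallest step the data allow. The true size of that step cannot be read, and the limit remains the usual result: the limit of > 100 ug/mL in this assay, at which 2 of the 3 values shown sit.

From the compounds shown here alone, how an amine, a carboxylic acid or a longer chain would behave at this position stays open.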